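This account rests on a few compounds, and the source may have more. Where it says the series, first, only, none or still open, it means among the compounds named here.

Measured compounds:
- compound 1, `Cc1cc(-c2cc(-c3cc(O)c(O)c([N+](=O)[O-])c3)on2)on1`, 32.4% in a functional assay on the whole organism (liver, strain NMRI) for inhibition, with Mus musculus as the target, with a stated time of 3 h, at a dose of 3 mg/kg by the oral route; a higher number here means more inhibition at the dose given (going by the name of the read-out), a lower number less inhibition
- compound 2, `O=[N+]([O-])c1cc(-c2cc(-c3ccncc3)no2)cc(O)c1O`, 32.1% in this assay
- compound 3, `O=[N+]([O-])c1cc(-c2cc(-c3cnccn3)no2)cc(O)c1O`, 44.7% in this assay

Compound 3 gives the highest of the three numbers: the steps of a number 12.3 percentage points higher from compound 1 to compound 3 (beyond the scatter) and a number 12.6 percentage points higher from compound 2 to compound 3 (beyond the scatter) are both beyond the scatter, while a number 0.3 percentage points lower from compound 1 to compound 2 (within the scatter) lies within it. Compound 4, `O=[N+]([O-])c1cc(-c2cc(-c3ccnc(F)c3)no2)cc(O)c1O`, differs from compound 3 in one place: 2-fluoropyridin-4-yl in place of pyrazin-2-yl on an aromatic carbon. The group that enters is a pyridin-4-yl carrying a fluorine, and the measured step that bears on it is the one where pyridin-4-yl was replaced by pyrazin-2-yl, a number 12.6 percentage points higher from compound 2 to compound 3 (beyond the scatter). Going back toward a pyridin-4-yl is therefore expected to undo part of that gain; what the fluorine adds is unknown. The expected step is a number 9.7 percentage points lower from compound 3 to compound 4 (within the scatter). Compound 4 is estimated at 35%, in a range from 22% to 48%.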

Compound 4, a percentage reported as inhibition, in the whole organism at one dose (the size of the read-out at that dose, not a potency): 18.7%
Compound 4: the middle estimate sits 16.3 percentage points above what was measured; measured number outside the range, below it.
By their numbers in this assay, from the lowest: compound 4; then compounds 2 and 1 (each within the scatter of the next); then compound 3.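

Adding one fluorine to the pyridin-4-yl group is enough to change the result in this assay (a number 13.4 percentage points lower from compound 2 to compound 4 (beyond the scatter)). Compound 1 and compound 2 lie within the scatter of each other, yet the 2-fluoropyridin-4-yl group falls clear of both the 3-methyl-1,2-oxazol-5-yl group (a number 13.7 percentage points lower from compound 1 to compound 4 (beyond the scatter)) and the pyrazin-2-yl group (a number 26 percentage points lower from compound 3 to compound 4 (beyond the scatter)). No measurement here explains what the fluorine does. On these data alone, whether a chlorine or an amine in the fluorine's place would also lower the inhibition stays open, as does the effect of a fluorine on the pyrazin-2-yl group.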